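Cyclopropyl to isopropyl: expecting little change in compound 3

A few compounds are considered here, and "the series" means these few. Any claim that something is new, unique, unknown or untested is made for them only; others in the source may bear on it.

Compound 1 `CC1(c2cc(NC(=O)n3ccc4cc(Oc5ncnc6c5CNC6)ccc43)n[nH]2)CC1`: 489000 nM
Compound 2 `O=C(Nc1cc(C2CC2)on1)n1ccc2cc(Oc3ncnc4c3CNC4)ccc21`: 110000 nM

In a physicochemical assay for solubility, at pH 6.8 (a lower number here means a less soluble compound, a higher number a more soluble compound), compound 2 gives the lower of the two numbers, 110000 nM. Compound 3 `CC(C)c1cc(NC(=O)n2ccc3cc(Oc4ncnc5c4CNC5)ccc32)no1` differs from it in one place: isopropyl in place of cyclopropyl on an aromatic carbon. Within the data shown here, only one measured step exists, a 4.4-fold lower number from compound 1 to compound 2 (0.65 log units; beyond the scatter). That modest step replaced a different group, so it offers no direct measure of this swap. With that little evidence, no change beyond the scatter is expected in this assay, and the estimated step is a 1.1-fold lower number from compound 2 to compound 3 (0.04 log units; within the scatter). The estimate for compound 3 is 100000 nM, with an expected range of 40000 nM to 250000 nM.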

Compound 3, solubility: 37000 nM
For compound 3 the middle estimate is 2.7-fold (0.43 log units) above the measured one; measured number below the stated range.
By their numbers in this assay, from the lowest: compound 3; then compound 2; then compound 1.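

In this assay this position is not indifferent: opening the cyclopropyl ring to isopropyl leaves the count of heavy atoms unchanged, yet it gives a 3.0-fold lower number from compound 2 to compound 3 (0.47 log units; beyond the scatter) and so moves the number beyond the scatter. Exchanging the whole group on the amide-type nitrogen gives a 13-fold lower number from compound 1 to compound 3 (1.12 log units; beyond the scatter) in the same assay, a large step. Nothing available here explains why these numbers fall. The compounds shown leave open how an amine, a carboxylic acid or a longer chain on this aromatic carbon would read.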